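Replacing (methoxymethoxy)methyl with diisopropylcarbamoyl on the shared core

A few compounds are considered here, and "the series" means these few. Any claim that something is new, unique, unknown or untested is made for them only; others in the source may bear on it.

In a functional assay on MCF7 cells (Homo sapiens) for antiproliferative activity, read by MTT assay, with a stated time of 48 h (on this read-out higher numbers stand for weaker inhibition and lower numbers for stronger inhibition), compound 1 (`CC(C)=CCC[C@]1(C)/C=C/[C@@H](OC(=O)C=C(C)C)[C@](C)(O)/C=C/C(=O)/C(CCl)=C\C1`) gives 610 nM, while compound 2 (`COCOC/C1=C/C[C@](C)(CCC=C(C)C)/C=C/[C@@H](OC(=O)C=C(C)C)[C@](C)(O)/C=C/C1=O`) gives 3120 nM, the higher of the two numbers and therefore the weaker inhibition. Compound 3 (`CC(C)=CCC[C@]1(C)/C=C/[C@@H](OC(=O)C=C(C)C)[C@](C)(O)/C=C/C(=O)/C(C(=O)N(C(C)C)C(C)C)=C\C1`) has not yet been measured. Its structure differs from that of compound 2 as follows: diisopropylcarbamoyl in place of (methoxymethoxy)methyl on a double-bonded ring carbon. In short, diisopropylcarbamoyl stands in place of (methoxymethoxy)methyl on a double-bonded ring carbon.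

Going by the values given here, only one measured step bears on this change. It is a 5.1-fold higher number from compound 1 to compound 2 (0.71 log units; beyond the scatter), a modest step in which methoxymethoxy replaces chloro on a saturated chain carbon bound to a double-bonded ring carbon. That step shows that a change in this substituent can move the number beyond the scatter. However, neither measured compound carries an amide, so the step gives no firm direction for compound 3. No clear shift from compound 2 is therefore expected, although the uncertainty is wide. The estimate means an expected 1.2-fold lower number from compound 2 to compound 3 (0.10 log units; within the scatter). In this assay, compound 3 is expected at 2500 nM, with an estimated range from 800 nM to 8000 nM.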

Compound 3, half-maximal inhibitory concentration: 17200 nM
Beside the measured number, compound 3's estimate is 6.9-fold (0.84 log units) below it; the whole stated range lies below it.
By their numbers in this assay, from the lowest: compound 1; then compound 2; then compound 3.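

In this assay, the diisopropylcarbamoyl group on this double-bonded ring carbon gives a 5.5-fold higher number from compound 2 to compound 3 (0.74 log units; beyond the scatter) and, against the chloromethyl group of the first compound, a 28-fold higher number from compound 1 to compound 3 (1.45 log units; beyond the scatter), so compound 3 is the weakest inhibitor of the three shown. Compounds 1 and 2 both carry a saturated chain carbon on this ring carbon, whereas compound 3 places an amide carbonyl directly on it, and this first change of that kind extends the upward direction already seen in a 5.1-fold higher number from compound 1 to compound 2 (0.71 log units; beyond the scatter) rather than reversing it. Nothing measured here on the compounds or their groups accounts for this loss of activity.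

The compounds shown leave open whether the higher number follows the amide carbonyl itself or the isopropyl groups on its nitrogen, and a dimethylcarbamoyl group or an unsubstituted carboxamide at this ring carbon would help to separate the two. They also leave open how a carboxylic acid or a hydroxymethyl group at the same place would compare with the chloromethyl group of compound 1.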